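Replacing 4-(dimethylamino)phenyl with pyridin-2-yl

The source may hold more compounds than are shown below. What is called first, only, known or untested is meant among the compounds shown, and "the series" means these compounds.

In a functional assay on HepG2 cells (Homo sapiens) for inhibition, read by MTT assay, with a stated time of 72 h (on this read-out lower numbers stand for stronger inhibition and higher numbers for weaker inhibition), compound 1 `Cc1ccccc1-c1cc(C(=O)N2CCC3(CC2)CC(=O)c2nn(C(C)(C)C)cc2O3)c2ccccc2n1` gives > 10000 nM, which is a limit and not a number. Going by the values given here, compound 2 `CN(C)c1ccc(-c2cc(C(=O)N3CCC4(CC3)CC(=O)c3nn(C(C)(C)C)cc3O4)c3ccccc3n2)cc1` gives 1730 nM, the only actual number so far. Compound 3 `CC(C)(C)n1cc2c(n1)C(=O)CC1(CCN(C(=O)c3cc(-c4ccccn4)nc4ccccc34)CC1)O2` has pyridin-2-yl in place of 4-(dimethylamino)phenyl, on the aromatic carbon next to the ring nitrogen (pyridin-2-yl in place of 4-(dimethylamino)phenyl on an aromatic carbon). Among the compounds with values here, that carbon has changed once already, in the only measured step, an at least 5.7-fold lower number from compound 1 to compound 2 (0.76 log units; beyond the scatter). On that single step, a move to a higher number is expected, an estimated 2.9-fold higher number from compound 2 to compound 3 (0.46 log units; beyond the scatter). In this assay the estimate for compound 3 is 5000 nM, with an expected range from 1500 nM to 15000 nM.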

Compound 3, half-maximal inhibitory concentration: 1500 nM
Estimate against measurement, compound 3: 3.3-fold (0.52 log units) above; the range from low to high includes it.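

At this carbon, next to the ring nitrogen, this assay does not separate pyridin-2-yl from 4-(dimethylamino)phenyl, with a 1.2-fold lower number from compound 2 to compound 3 (0.06 log units; within the scatter). The dimethylamino group is therefore not required for a measurable value, and among the three groups shown only 2-methylphenyl stands apart, with an at least 6.6-fold lower number from compound 1 to compound 3 (0.82 log units; beyond the scatter). Compound 1 is known only as a limit, so both of its steps are open-ended: the limit of > 10000 nM in this assay, at which 1 of the 3 values shown sits.

From the compounds shown here alone, whether a saturated amine such as morpholine or a carboxylic acid at this carbon would read the same remains open. Only six-membered aromatic rings are shown here.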